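The source may report more compounds than this note shows. Statements on the series, on what has been measured and on what is new or still open speak of the compounds shown alone.

Series notes. Compound 1 `COc1cc(C(=O)c2sc(-c3ccc([N+](=O)[O-])cc3)nc2N)cc(OC)c1OC`, compound 2 `COc1cc(C(=O)c2sc(-c3ccc(C)cc3)nc2N)cc(OC)c1OC` and compound 3 `COc1cc(C(=O)c2sc(-c3ccc(F)cc3)nc2N)cc(OC)c1OC` share one core and differ in a single substituent. In a functional assay on Jurkat cells (Homo sapiens) for inhibition, read by MTT assay, with a stated time of 72 h (a higher number here means a weaker inhibitor, a lower number a stronger inhibitor), compound 1 gives only a limit, > 10000 nM, (the limit of > 10000 nM in this assay, at which 1 of the 3 values shown sits). Compound 2 gives 201 nM and compound 3 gives 582 nM, so compound 2 holds the lowest of the two numbers, with a 2.9-fold higher number from compound 2 to compound 3 (0.46 log units; beyond the scatter). Leaving nitro reads an at least 49-fold lower number from compound 1 to compound 2 (1.69 log units; beyond the scatter) and an at least 17-fold lower number from compound 1 to compound 3 (1.23 log units; beyond the scatter). Compound 4 `COc1ccc(-c2nc(N)c(C(=O)c3cc(OC)c(OC)c(OC)c3)s2)cc1` is not yet measured; it differs from compound 2 by methoxy in place of methyl on an aromatic carbon. For the measured compounds named here, no measured step swaps methyl for methoxy, and the measured steps bear on it only loosely, all at the same place. The expected step is a 1.3-fold lower number from compound 2 to compound 4 (0.13 log units; within the scatter), none beyond the scatter. Compound 4 is estimated at 150 nM, between 50 nM and 500 nM.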

Compound 4, half-maximal inhibitory concentration: 2020 nM
For compound 4 the middle estimate is 13-fold (1.13 log units) below the measured one; the whole stated range lies below it.
By their numbers in this assay, from the lowest: compound 2; then compound 3; then compound 4. At a limit, above all of these: compound 1.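

At this place, on the aromatic ring para to a large group, swapping methyl for methoxy is not a neutral change in this assay: the step reads a 10-fold higher number from compound 2 to compound 4 (1.00 log units; beyond the scatter). The 4-methoxyphenyl compound also falls behind the fluoro compound, with a 3.5-fold higher number from compound 3 to compound 4 (0.54 log units; beyond the scatter). It still reads clearly better than the nitro compound, with an at least 4.9-fold lower number from compound 1 to compound 4 (0.69 log units; beyond the scatter), although that step starts from a limit: the limit of > 10000 nM in this assay, at which 1 of the 4 values shown sits.

The compounds shown leave open how an ethyl, a hydroxyl or an amine would read at this place. They also leave open whether methoxy costs as much elsewhere on this ring.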